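Series notes: aryl-to-alkenyl exchange at the sulfur-adjacent carbon

This account rests on a few compounds, and the source may have more. Where it says the series, first, only, none or still open, it means among the compounds named here.

Measured so far:
compound 1 `CC(C)(C)Cc1c(-c2ccoc2)sc(N)c1C(=O)c1ccc(Cl)cc1` — 1%
compound 2 `CC(C)(C)Cc1c(-c2ccc(F)cc2F)sc(N)c1C(=O)c1ccc(Cl)cc1` — 1%
compound 3 `CC(C)(C)Cc1c(-c2cc(F)ccc2F)sc(N)c1C(=O)c1ccc(Cl)cc1` — 3%

All three compounds share the same core and differ only in the group on the aromatic carbon of the five-membered ring. In an assay on CHO cells for displacement of a labelled ligand from adenosine receptor A1 (Homo sapiens), read by scintillation counting, tested at 10 uM (on this read-out lower numbers stand for less inhibition and higher numbers for more inhibition at the one concentration tested (going by the name of the read-out)), compound 1 gives 1% and compound 2 gives 1%; the step of no change at the digits printed from compound 1 to compound 2 (within the scatter) is within the scatter. Compound 3 gives 3%, and both a number 2 percentage points higher from compound 1 to compound 3 (within the scatter) and a number 2 percentage points higher from compound 2 to compound 3 (within the scatter) are also within the scatter. The three numbers therefore do not separate from one another, and compound 3 stands at the same level as the other two.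

Compound 4 `CC(C)(C)Cc1c(/C=C/c2ccc(Cl)cc2)sc(N)c1C(=O)c1ccc(Cl)cc1` is not yet measured. It differs from compound 3 as follows: 2-(4-chlorophenyl)ethenyl in place of 2,5-difluorophenyl on an aromatic carbon. The measured steps that bear on this position, furan-3-yl to 2,4-difluorophenyl and to 2,5-difluorophenyl and the exchange between the two difluorophenyl groups, were all without change beyond the scatter. Within the data shown here, no measured step tests an alkenyl chain in this place, so no direction can be read from the data. Compound 4 is expected to stay at the same level, with a number 1 percentage points higher from compound 3 to compound 4 (within the scatter) expected to lie within the scatter. The estimate for compound 4 is 4%, with a range from -5% to 15%.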

Compound 4, a percentage reported as inhibition, at one concentration (the size of the read-out at that concentration, not a potency): 1%
Beside the measured number, compound 4's estimate is 3 percentage points above it; the range from low to high includes it.
By their numbers in this assay, from the lowest: compounds 1, 2, 4 and 3 (each within the scatter of the next).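

In this assay, the 2-(4-chlorophenyl)ethenyl group on the aromatic carbon next to the ring sulfur gives a number 2 percentage points lower from compound 3 to compound 4 (within the scatter) and no change at the digits printed from compound 2 to compound 4 (within the scatter) and no change at the digits printed from compound 1 to compound 4 (within the scatter) in the three comparisons with the directly attached rings. The series now includes a group with a double bond outside aromatic rings at this place, and the read-out at the one concentration tested stays at the same level as with furan-3-yl, 2,4-difluorophenyl and 2,5-difluorophenyl, so this change adds no measurable inhibition in these compounds. No supporting measurement is available to account for this flat result.

As far as these compounds go, it remains open whether any group at this place can raise the read-out, as the four compounds show only aromatic rings and one aryl-bearing alkenyl chain there, and a basic amine such as a piperidine, a carboxylic acid or a plain saturated alkyl chain would test quite different groups. From the compounds shown here alone, with the neopentyl, amino and (4-chlorophenyl)carbonyl groups held constant throughout, it is also open whether the flat level belongs to this position or to the shared core as a whole.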